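Inverting one stereocentre on a shared sulfonamide core

The compounds below may be only part of what the source reports. "The series", "measured", "known", "first", "only" and "open" are said of these compounds alone.

Three compounds share a common core and differ only in the aryl group carrying the fluorinated carbinol. Compound 1 `CC#C[C@H]1CN(S(=O)(=O)c2ccc(N)nc2)CCN1c1ccc([C@@](O)(CO)C(F)(F)F)cc1` was tested in an ADME assay (liver) for metabolic stability, with Liver microsome (Rattus norvegicus) as the target, using microsomes and NADPH, with a stated time of 30 min (on this read-out higher numbers stand for fast clearance and lower numbers for slow clearance), where compound 1 gives 53 mL.min-1.g-1. Compound 2 `CC#C[C@H]1CN(S(=O)(=O)c2ccc(N)nc2)CCN1c1ccc(C(O)(C(F)(F)F)C(F)(F)F)cn1` gives 42 mL.min-1.g-1 in this assay, and compound 3 `CC#C[C@H]1CN(S(=O)(=O)c2ccc(N)nc2)CCN1c1ncc(C(O)(C(F)(F)F)C(F)(F)F)cn1` gives 28 mL.min-1.g-1. Compound 1 carries the largest number of the three as read, yet neither its gap to compound 2 nor its gap to compound 3 exceeds the usual scatter, so the three cannot truly be told apart on this read-out.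

The next compound, compound 4 `CC#C[C@H]1CN(S(=O)(=O)c2ccc(N)nc2)CCN1c1ccc([C@](O)(CO)C(F)(F)F)cc1`, is a mirror-image variant at a single point: the two compounds have the same atoms and bonds and differ only in configuration as drawn: 1 of 2 stereo elements differ; a stereocentre at a saturated chain carbon is drawn R in compound 1 and S in compound 4. No atom is added or removed. Among the compounds with values here, with no measured pair of such stereochemical partners to lean on, the most defensible expectation is that the step from compound 1 to compound 4 is small: a 1.1-fold lower number from compound 1 to compound 4 (0.03 log units; within the scatter) is expected to lie within the scatter, in no particular direction. Compound 4 is therefore estimated at 50 mL.min-1.g-1, with a range from 25 mL.min-1.g-1 to 100 mL.min-1.g-1.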

Compound 4, intrinsic clearance in microsomes: < 14 mL.min-1.g-1
Compound 4: only a limit was reported (the forecaster's own chance of this, stated with the estimate: 5%); middle value at least 3.5-fold (0.55 log units) away from the limit.
By their numbers in this assay, from the lowest: compounds 3, 2 and 1 (each within the scatter of the next). At a limit, below all of these: compound 4.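

Within the data shown here, changing only the stereocentre at a saturated chain carbon, drawn R in compound 1 and S in compound 4, gives an at least 3.7-fold lower number from compound 1 to compound 4 (0.57 log units; beyond the scatter) in this assay, the first step here between two compounds that differ in one place. The reported value for compound 4, < 14 mL.min-1.g-1, is a limit of the assay. With no atom added or removed, this step can be put down to the configuration at that one carbon, and the earlier compounds could not show this because no two of them formed such a pair: the fact that compounds 1 and 4 differ only in the configuration as drawn

As far as these compounds go, whether inverting the other stereocentre has a comparable effect remains open. So does whether the number stays this low when an amine or a carboxylic acid is attached to the inverted carbon.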